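Urea series, cytotoxicity: fluorophenyl for methylpyridinyl

A few compounds are considered here, and "the series" means these few. Any claim that something is new, unique, unknown or untested is made for them only; others in the source may bear on it.

In an ADME assay on HepG2 cells (Homo sapiens) for cytotoxicity, with a stated time of 72 h (on this read-out higher numbers stand for an effect only at larger amounts of compound and lower numbers for an effect already at smaller amounts), compound 1 `COc1ccc(NC(=O)Nc2cc(C)nc3ccccc23)cc1` returns only a limit, > 25000 nM. Compound 2 `COc1ccc(NC(=O)Nc2cc(C)nc3ccccc23)cc1F` likewise returns only a limit in this assay, > 25000 nM. For the measured compounds named here, the one step between measured neighbours, a step that the two limits leave unreadable from compound 1 to compound 2, is therefore unreadable. Compound 3 `Cc1cc(NC(=O)Nc2ncccc2C)c2ccccc2n1` stands at the same limit in this assay, > 25000 nM. Thus the limit of > 25000 nM in this assay, at which 3 of the 3 values shown sit, holds for every value shown, and compound 3 cannot be placed against the other two. Compound 4 `Cc1cc(NC(=O)Nc2ccccc2F)c2ccccc2n1` differs from compound 3 by 2-fluorophenyl in place of 3-methylpyridin-2-yl on an amide-type nitrogen. No measured step bears on this change, and the single step shown gives no size. Compound 4 is expected to remain at the limit. The expected step that the limit leaves unreadable from compound 3 to compound 4 is estimated to lie within the scatter. The estimate for compound 4 in this assay is 30000 nM, within 10000 nM to 100000 nM.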

Compound 4, half-maximal effective concentration: > 25000 nM
Compound 4 was reported as a limit; the forecaster's own chance of this, stated with the estimate: 85%; the middle value does not contradict the limit.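

Compound 3 and compound 4 both return only limits, so no step between them can be read: the limit of > 25000 nM in this assay, at which 4 of the 4 values shown sit.

The compounds shown leave open whether 2-fluorophenyl or 3-methylpyridin-2-yl makes any difference in this assay, since none gives a readable value.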